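Anilide solubility after a difluorophenyl replacement

The source may hold more compounds than are shown below. What is called first, only, known or untested is meant among the compounds shown, and "the series" means these compounds.

Compound 1 `COc1ccc2nc(C)cc(OCC(=O)NCc3cc(C)cc(C)c3)c2c1` gives 92000 nM in a physicochemical assay for solubility, in phosphate buffer, measured as kinetic solubility, with a stated time of 1 h, at pH 7.4; a higher number here means a more soluble compound, a lower number a less soluble compound.
Compound 2 `COc1ccc2nc(C)cc(OCC(=O)Nc3c(C)cccc3C)c2c1` gives 112000 nM in this assay.
For compound 3 `COc1ccc2nc(C)cc(OCC(=O)Nc3ccc(Br)c(C)c3)c2c1` the reading < 1000 nM is a limit of this assay, not a number.

Compound 3 therefore stands at the bottom of the three, at the limit described by the limit of < 1000 nM in this assay, at which 1 of the 3 values shown sits, and how far below the other two it truly lies is not known. The two measured steps that reach it are an at least 92-fold lower number from compound 1 to compound 3 (1.96 log units; beyond the scatter) and an at least 110-fold lower number from compound 2 to compound 3 (2.04 log units; beyond the scatter); both are large and in the same direction, whereas a 1.2-fold higher number from compound 1 to compound 2 (0.09 log units; within the scatter) shows that the two dimethyl-substituted compounds sit together.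

Compound 4 `COc1ccc2nc(C)cc(OCC(=O)Nc3cc(F)cc(F)c3)c2c1` differs from compound 3 by 3,5-difluorophenyl in place of 4-bromo-3-methylphenyl on an amide-type nitrogen. This removes the 4-bromo-3-methylphenyl group that accompanies the large fall in compounds 1 and 2 toward compound 3, and the two steps that bear on it, an at least 92-fold lower number from compound 1 to compound 3 (1.96 log units; beyond the scatter) and an at least 110-fold lower number from compound 2 to compound 3 (2.04 log units; beyond the scatter), were both beyond the scatter. A rise in this assay is expected, though its size is uncertain since compound 3 is only known as a limit; the expected step is an at least 10-fold higher number from compound 3 to compound 4 (1.00 log units; beyond the scatter). Compound 4 is estimated at 10000 nM, within a range from 1500 nM to 60000 nM.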

Compound 4, solubility: 13000 nM
Estimate against measurement, compound 4: 1.3-fold (0.11 log units) below, and the stated range covers the measured number.
By their numbers in this assay, from the lowest: compound 4; then compounds 1 and 2 (each within the scatter of the next). At a limit, below all of these: compound 3.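

With 3,5-difluorophenyl in place of 4-bromo-3-methylphenyl on the amide-type nitrogen, the series returns to a measured reading in this assay, giving an at least 13-fold higher number from compound 3 to compound 4 (1.11 log units; beyond the scatter). Going by these compounds, that step starts from a reading that is a limit and not a number, so its true size remains unknown: the limit of < 1000 nM in this assay, at which 1 of the 4 values shown sits. The return is only partial, as the other two steps at this position are an 8.6-fold lower number from compound 2 to compound 4 (0.94 log units; beyond the scatter) and a 7.1-fold lower number from compound 1 to compound 4 (0.85 log units; beyond the scatter), so the three groups that give numbers here fall into two levels, while the 4-bromo-3-methylphenyl compound stands apart at its limit.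

The compounds shown leave open whether the bromine, the methyl or the two together go with the low reading, since 4-bromo-3-methylphenyl appears only as a whole, and a phenyl carrying bromine alone or methyl alone would separate them. Also open, on these data alone, is how a difluorobenzyl group would read on the same nitrogen, and whether a pyridine ring or a phenyl bearing a carboxylic acid or an amine would lie nearer to the dimethyl-substituted compounds.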